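This account rests on a few compounds, and the source may have more. Where it says the series, first, only, none or still open, it means among the compounds named here.

Working notes on the series.

Compound 3 `FC(F)(F)c1cccc2cc(-c3nn[nH]n3)cnc12` gives 25 mg/kg in a functional assay on the whole organism (strain Sprague-Dawley) for inhibition, with Rattus norvegicus as the target; on this read-out lower numbers stand for an effect already at smaller amounts and higher numbers for an effect only at larger amounts of compound. That puts compound 3 level with compound 1 `c1ccc2ncc(-c3nn[nH]n3)cc2c1`, which gives 25 mg/kg; together these are the two highest numbers of the three, with no change at the digits printed from compound 1 to compound 3 (within the scatter). Compound 2 `CCc1cccc2cc(-c3nn[nH]n3)cnc12` gives 5 mg/kg and stands apart, with a 5.0-fold higher number from compound 2 to compound 3 (0.70 log units; beyond the scatter).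

Compound 4 `COc1cccc2cc(-c3nn[nH]n3)cnc12` is the next member to be tested. Compared with compound 3 the change is methoxy in place of trifluoromethyl on an aromatic carbon.

Bearing on this step: the substituent at this aromatic carbon has mattered. Going to an ethyl gave a 5.0-fold lower number from compound 1 to compound 2 (0.70 log units; beyond the scatter), whereas a trifluoromethyl gave no change at the digits printed from compound 1 to compound 3 (within the scatter), and replacing the ethyl by trifluoromethyl gave a 5.0-fold higher number from compound 2 to compound 3 (0.70 log units; beyond the scatter). For the measured compounds named here, a methoxy has no direct precedent among the three compounds measured; the two groups tested so far span the whole range seen. The expectation is therefore a number between those of compound 2 and compound 3, i.e. a modest lowering from compound 3, a 2.5-fold lower number from compound 3 to compound 4 (0.40 log units; beyond the scatter), with wide uncertainty. For compound 4 the estimate is 10 mg/kg, with a range from 4 mg/kg to 30 mg/kg.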

Compound 4, minimum effective dose: > 25 mg/kg
Compound 4 ended at the assay's limit (the forecaster's own chance of this, stated with the estimate: 5%); middle value at least 2.5-fold (0.39 log units) away from the limit.
By their numbers in this assay, from the lowest: compound 2; then compounds 1 and 3 (each within the scatter of the next).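

The reading for compound 4 in this assay is a limit of the assay and not a number: the limit of > 25 mg/kg in this assay, at which 1 of the 4 values shown sits. Methoxy in place of trifluoromethyl gives a number no lower from compound 3 to compound 4 (the limit leaves the size open). Methoxy in place of ethyl gives an at least 5.0-fold higher number from compound 2 to compound 4 (0.69 log units; beyond the scatter), so the lower number at this aromatic carbon does not carry over to this small oxygen-linked group. Methoxy in place of hydrogen gives a number no lower from compound 1 to compound 4 (the limit leaves the size open). These two steps with an open size cannot be read for size and show only that methoxy brings no lower number than hydrogen or trifluoromethyl, leaving ethyl as the only group shown here with a lower number than hydrogen.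

On these data alone, it remains open how far the value of compound 4 lies beyond the limit. As far as these compounds go, it is also open whether a longer chain such as propyl, or an amine, at this carbon would keep the lower number seen with ethyl.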